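The source may report more compounds than this note shows. Statements on the series, on what has been measured and on what is new or still open speak of the compounds shown alone.

Compound 3 `COc1cccc(CNCCCNc2ccnc3cc(Cc4ccccc4)ccc23)c1O` sits at the low end of the permeability numbers gathered so far. In an ADME assay for permeability, using PAMPA, with a stated time of 30 min, at pH 7.4 (on this read-out lower numbers stand for lower permeability and higher numbers for higher permeability), compound 3 gives 23 10^-6 cm/s. Compound 2 `CC(C)CCc1ccc2c(NCCCNCc3ccco3)ccnc2c1` gives 23 10^-6 cm/s, level with compound 3 at the digits shown. Among the measured compounds shown here, compound 1 `COc1cccc(CNCCCNc2ccnc3cc(Oc4ccc(Cl)cc4)ccc23)c1O` gives 317 10^-6 cm/s, and the one step measured, a 14-fold lower number from compound 1 to compound 3 (1.14 log units; beyond the scatter), is large.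

Compound 4 `COc1cccc(CNCCCNc2ccnc3cc(CCC(C)C)ccc23)c1O` keeps the whole of compound 3 except at one spot: isobutyl in place of phenyl on a saturated chain carbon bound to an aromatic carbon. For the measured compounds named here, no measured step covers this exact change. Going by the values given here, the only step known, from compound 1 to compound 3, concerns a different group at the aromatic carbon, so it does not bear on it directly. Compound 2 carries the same isopentyl group that compound 4 receives, though its other chain differs, and its value matches that of compound 3.

On that basis compound 4 is expected to show little or no change beyond the scatter, a 1.1-fold higher number from compound 3 to compound 4 (0.04 log units; within the scatter), and its estimated value is 25 10^-6 cm/s, within 10 10^-6 cm/s to 60 10^-6 cm/s.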

Compound 4, apparent permeability: 23 10^-6 cm/s
Compound 4: middle estimate off by 1.1-fold (0.04 log units), on the high side, within the range that was stated.
By their numbers in this assay, from the lowest: compounds 2, 3 and 4 (each within the scatter of the next); then compound 1.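

In this assay, isobutyl in place of phenyl on a saturated chain carbon bound to an aromatic carbon gives no change at the digits printed from compound 3 to compound 4 (within the scatter), so losing the phenyl ring there leaves the number unmoved. Among the compounds shown here, the first reading at the other place, 2-hydroxy-3-methoxyphenyl in place of furan-2-yl on a saturated chain carbon bound to an amine nitrogen, likewise gives no change at the digits printed from compound 2 to compound 4 (within the scatter). Replacing 4-chlorophenoxy with isopentyl on an aromatic carbon, by contrast, gives a 14-fold lower number from compound 1 to compound 4 (1.14 log units; beyond the scatter), matching a 14-fold lower number from compound 1 to compound 3 (1.14 log units; beyond the scatter), so among the three groups shown on that carbon, only 4-chlorophenoxy stands apart, while benzyl and isopentyl are level.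

Nothing available explains why 4-chlorophenoxy stands apart. On these data alone, whether its number follows the ether oxygen or the chlorine stays open, and a phenoxy or a 4-chlorobenzyl group on that aromatic carbon would tell these apart.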